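Swapping a dimethylphenyl for a hydroxyphenyl on the shared core

The compounds below may be only part of what the source reports. "The series", "measured", "known", "first", "only" and "open" are said of these compounds alone.

- compound 1 `COc1ccc(-c2ccc3ncn(-c4cc(OC)c(OC)c(OC)c4)c3c2)cc1O` with 200 nM
- compound 2 `COc1cc(-n2cnc3ccc(-c4cccc(C)c4C)cc32)cc(OC)c1OC` with 9250 nM

In a functional assay on A549 cells (Homo sapiens) for antiproliferative activity, read by MTT assay, with a stated time of 72 h (a lower number here means a stronger inhibitor, a higher number a weaker inhibitor), compound 2 stands highest of the two with 9250 nM while compound 1 sits nearest with 200 nM as its number. Compound 3 `COc1cc(-n2cnc3ccc(-c4ccc(O)cc4)cc32)cc(OC)c1OC` differs from compound 2 by one swap (4-hydroxyphenyl in place of 2,3-dimethylphenyl on an aromatic carbon), 4-hydroxyphenyl in place of 2,3-dimethylphenyl. Among the compounds with values here, the only measured step bearing on this is large and beyond the scatter: a 46-fold higher number from compound 1 to compound 2 (1.67 log units; beyond the scatter) came with 2,3-dimethylphenyl replacing 3-hydroxy-4-methoxyphenyl. Compound 3 regains a hydroxyphenyl group but lacks the methoxy, so a clear drop in this assay is expected, probably smaller than that full step. The estimated change is a 6.2-fold lower number from compound 2 to compound 3 (0.79 log units; beyond the scatter) in size. For compound 3 the expected value is 1500 nM within an estimated range of 300 nM to 7000 nM overall.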

Compound 3, half-maximal inhibitory concentration: 5090 nM
Beside the measured number, compound 3's estimate is 3.4-fold (0.53 log units) below it; low and high end bracket the measured number.
By their numbers in this assay, from the lowest: compound 1; then compounds 3 and 2 (each within the scatter of the next).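

In this assay, placing 4-hydroxyphenyl on this aromatic carbon instead of 2,3-dimethylphenyl gives a 1.8-fold lower number from compound 2 to compound 3 (0.26 log units; within the scatter), so among these compounds, a hydroxyl on the ring does not by itself separate the two. Replacing 3-hydroxy-4-methoxyphenyl with 4-hydroxyphenyl gives a 25-fold higher number from compound 1 to compound 3 (1.41 log units; beyond the scatter), so compound 1 keeps a clear edge that 4-hydroxyphenyl does not recover.

On these data alone, whether a phenyl ring carrying an amine or a carboxylic acid here would come closer to compound 1 remains open. Nothing shown explains why these steps differ in size.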